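Cytotoxicity Limits Across Three Acrylamide Analogues

The source may report more compounds than this note shows. Statements on the series, on what has been measured and on what is new or still open speak of the compounds shown alone.

Compound 1 `Cc1cc(C#N)cc(C)c1Oc1nc(Nc2ccc(C#N)cc2)ncc1/C=C/C(N)=O`, in an ADME assay on TZM cells (Homo sapiens) for cytotoxicity, with a stated time of 1 days (a lower number here means that less compound is tolerated, a higher number that more compound is tolerated), compound 1 gives > 243 nM, a limit.
Compound 2 `Cc1cc(C#N)cc(C)c1Oc1nc(Nc2ccc(C#N)cc2)ncc1/C=C/C(=O)NC1CC1`, in this assay compound 2 gives > 221 nM, a limit.
Compound 3 `Cc1cc(C#N)cc(C)c1Oc1nc(Nc2ccc(C#N)cc2)ncc1/C=C/C(=O)NCCOCCO`, in this assay compound 3 gives > 200 nM, a limit.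

Compound 3 stands at a limit, as do the two other values shown (the limit of > 200 nM in this assay, at which 1 of the 3 values shown sits, (the limit of > 221 nM in this assay, at which 1 of the 3 values shown sits), (the limit of > 243 nM in this assay, at which 1 of the 3 values shown sits)). Because all three values are limits, the steps a step that the two limits leave unreadable from compound 1 to compound 2, a step that the two limits leave unreadable from compound 1 to compound 3 and a step that the two limits leave unreadable from compound 2 to compound 3 cannot be read in size or direction.

Compound 4 `Cc1cc(C#N)cc(C)c1Oc1nc(Nc2ccc(C#N)cc2)ncc1/C=C/C(=O)NC1CCN(S(C)(=O)=O)CC1` differs from compound 3 by 1-(methylsulfonyl)piperidin-4-yl in place of 2-(2-hydroxyethoxy)ethyl on an amide-type nitrogen. Every measured step at the amide-type nitrogen bears on this change, yet none of them is readable, so no direction can be drawn from them. What the three values do show is that none of the tested compounds produced a readable cytotoxic concentration within the tested range.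

Compound 4 is therefore expected to behave in this assay much like the others, with a step that the limit leaves unreadable from compound 3 to compound 4 that would not be readable. The estimate for compound 4 in this assay is 300 nM, within 150 nM to 1200 nM, most likely reported again as a limit.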

Compound 4, half-maximal cytotoxic concentration: > 175 nM
Compound 4: a limit, no number; the forecaster's own chance of this, stated with the estimate: 80%; the middle value lies beyond the limit too.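

In this assay compound 4 gives > 175 nM, again a limit, so its steps from compound 1, compound 2 and compound 3 cannot be read in size or direction. The compounds shown leave open where the half-maximal cytotoxic concentration of any of the four actually lies.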